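The compounds below may be only part of what the source reports. "The series", "measured", "known", "first", "only" and "open" are said of these compounds alone.

Compound 2, with the structure `CCC(=O)O[C@@H](/C(C)=C/[C@@H](C)c1oc(CC)c(C)c(=O)c1C)[C@H](C)[C@@H](OC(=O)CC(C)C)[C@@H](C)c1oc([C@@H](C)[C@H](CC)OC(C)=O)c(C)c(=O)c1C`, stands at the lower of the two numbers seen so far: in a functional assay on Hs 683 cells (Homo sapiens) for inhibition, read by MTT assay, with a stated time of 72 h (on this read-out lower numbers stand for stronger inhibition and higher numbers for weaker inhibition), compound 2 gives 3000 nM, whereas compound 1, the structure `CCc1oc([C@H](C)/C=C(\C)[C@H](OC(C)=O)[C@H](C)[C@@H](OC(=O)CC(C)C)[C@@H](C)c2oc([C@@H](C)[C@@H](O)CC)c(C)c(=O)c2C)c(C)c(=O)c1C`, gives 30000 nM in this assay, a gap that is described as beyond the usual scatter. Within the data shown here, no single-point step connects these two compounds, so their values can only be set side by side.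

Compound 3, the structure `CCC(=O)O[C@@H](/C(C)=C/[C@@H](C)c1oc(CC)c(C)c(=O)c1C)[C@H](C)[C@@H](OC(=O)CC(C)C)[C@@H](C)c1oc([C@@H](C)[C@@H](O)CC)c(C)c(=O)c1C`, is the next compound to be measured. It differs from compound 2 in one place: hydrogen in place of acetyl on an oxygen on a saturated carbon

Among the measured compounds shown here, the change from acetoxy to hydroxy is the only alteration, and no measured pair shows this change on its own. Compound 1, the weaker compound, also carries a hydroxy rather than an acetoxy, but its other differences prevent any clean reading. A weakening step is therefore expected, of moderate size, namely a 2.7-fold higher number from compound 2 to compound 3 (0.43 log units; beyond the scatter). Compound 3 is estimated at 8000 nM in this assay, within a range from 2500 nM to 30000 nM.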

Compound 3, half-maximal inhibitory concentration: 13000 nM
Compound 3: the middle estimate sits 1.6-fold (0.21 log units) below what was measured, within the range that was stated.
By their numbers in this assay, from the lowest: compound 2; then compound 3; then compound 1.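

In this assay, the step from 2-acetoxy-1-methylbutyl to 2-hydroxy-1-methylbutyl can now be read on its own: it gives a 4.3-fold higher number from compound 2 to compound 3 (0.64 log units; beyond the scatter) and shows that inhibition at this position weakens when the acetyl is lost. A second place also matters, as methyl in place of hydrogen on a saturated chain carbon bound to a carbonyl carbon gives a 2.3-fold lower number from compound 1 to compound 3 (0.36 log units; beyond the scatter) in the direction of stronger inhibition. Nothing available explains either step.

The compounds shown leave open whether the acetyl itself matters or any acyl group on this oxygen would serve equally, as a benzoyl ester might show, and whether a methyl ether or an amine at this place would behave like the acetoxy or the hydroxy. They also leave open whether a longer chain at the second place would continue the step seen there.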